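This account rests on a few compounds, and the source may have more. Where it says the series, first, only, none or still open, it means among the compounds named here.

- compound 1 `O=C(CN1CCCCC1)OC1CC2(N3CCCC3)CC(c3ccccc3)C1C(c1ccccc1)C2`: 14200 nM
- compound 2 `CN(C)C12CC(OC(=O)CCN3CCCC3)C(C(c3ccccc3)C1)C(c1ccccc1)C2`: 26000 nM

In an ADME assay on L6 cells (Rattus norvegicus) for cytotoxicity (a lower number here means a stronger inhibitor, a higher number a weaker inhibitor), compound 2 gives 26000 nM, and compound 1 gives 14200 nM. These two values lie within the usual scatter of repeated measurements, so the data do not separate them and compound 2 cannot be ranked against compound 1.

Compound 3 `O=C(CCN1CCCC1)OC1CC2(N3CCCC3)CC(c3ccccc3)C1C(c1ccccc1)C2` has not been measured yet. It has pyrrolidin-1-yl in place of dimethylamino on a saturated ring carbon of compound 2: pyrrolidin-1-yl in place of dimethylamino on a saturated ring carbon. The new group is a five-membered non-aromatic ring, whereas the group it replaces has no ring. The rest of compound 2 stays the same, including the ((2-(pyrrolidin-1-yl)ethyl)carbonyl)oxy group.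

Going by the values given here, no measured pair shows this change on its own, so the data give no direct size for it. In this assay, the expectation is therefore a step no larger than the scatter, with no favoured direction. The expected change is a 1.3-fold lower number from compound 2 to compound 3 (0.11 log units; within the scatter). For compound 3 the estimated value is 20000 nM, with an expected range of 8000 nM to 50000 nM.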

Compound 3, half-maximal inhibitory concentration: 21900 nM
Compound 3: middle estimate off by 1.1-fold (0.04 log units), on the low side; the measured number falls inside the stated range.
By their numbers in this assay, from the lowest: compounds 1, 3 and 2 (each within the scatter of the next).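

In this assay, putting pyrrolidin-1-yl in place of dimethylamino on a saturated ring carbon gives a 1.2-fold lower number from compound 2 to compound 3 (0.07 log units; within the scatter), so at this position a five-membered non-aromatic ring cannot be told apart from a group with no ring. The second change, (pyrrolidin-1-yl)methyl in place of piperidin-1-yl on a saturated chain carbon bound to a carbonyl carbon, gives a 1.5-fold higher number from compound 1 to compound 3 (0.19 log units; within the scatter), so it too cannot be told apart from no change, and the three compounds still cannot be ranked against one another. No separate measurement bears on this result.

The compounds shown leave open whether a different kind of group on that saturated ring carbon, such as a primary amine or a carboxylic acid, would shift the number beyond the scatter. They also leave open whether a longer chain carrying the pyrrolidin-1-yl group on the carbonyl would do so.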